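A few compounds are considered here, and "the series" means these few. Any claim that something is new, unique, unknown or untested is made for them only; others in the source may bear on it.

Compound 3 `CN1CCC(c2c[nH]c3ccc(NC(=O)c4cccs4)nc23)CC1` gives 390 nM in an assay for binding affinity to 5-hydroxytryptamine receptor 1B (Homo sapiens), read by radioligand binding (on this read-out higher numbers stand for weaker inhibition and lower numbers for stronger inhibition), the second highest of the three numbers. Compound 2 `CN1CCC(c2c[nH]c3ccc(NC(=O)c4ccc([N+](=O)[O-])cc4)nc23)CC1` gives 270 nM, and the two lie within the scatter of each other, while compound 1 `CN1CCC(c2c[nH]c3ccc(NC(=O)C4CC4)nc23)CC1` gives 1700 nM, with a 4.4-fold lower number from compound 1 to compound 3 (0.64 log units; beyond the scatter) between them. Compound 4 `CN1CCC(c2c[nH]c3ccc(OS(C)(=O)=O)nc23)CC1` differs from compound 3 by (methylsulfonyl)oxy in place of ((thiophen-2-yl)carbonyl)amino on an aromatic carbon. Going by the values given here, no measured step removes the amide itself: a 6.3-fold lower number from compound 1 to compound 2 (0.80 log units; beyond the scatter) and a 4.4-fold lower number from compound 1 to compound 3 (0.64 log units; beyond the scatter) only vary the group on its carbonyl carbon, and both steps were modest. With the acyl group and its aromatic ring gone, the number for compound 4 is expected to rise, roughly a 3.8-fold higher number from compound 3 to compound 4 (0.59 log units; beyond the scatter), back toward the number of compound 1. The estimate for compound 4 is 1500 nM, within 400 nM to 6000 nM.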

Compound 4, inhibition constant: 25 nM
For compound 4 the middle estimate is 60-fold (1.78 log units) above the measured one; the whole stated range lies above it.
By their numbers in this assay, from the lowest: compound 4; then compounds 2 and 3 (each within the scatter of the next); then compound 1.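

The amide is not required on this aromatic carbon: with (methylsulfonyl)oxy in place of the whole ((thiophen-2-yl)carbonyl)amino group, there is a 16-fold lower number from compound 3 to compound 4 (1.19 log units; beyond the scatter), and in place of (cyclopropylcarbonyl)amino, a 68-fold lower number from compound 1 to compound 4 (1.83 log units; beyond the scatter). Going by these compounds alone, both steps are large and exceed the earlier steps that varied only the group on the carbonyl carbon, even though the entering group has no ring and no hydrogen-bond donor. Nothing available explains this gain. Going by these compounds, it remains open whether the gain belongs to the methylsulfonyl group or to the oxygen attaching it to the ring. A methanesulfonamide or a methoxy group on this carbon would help separate the two.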